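The source may report more compounds than this note shows. Statements on the series, on what has been measured and on what is new or still open speak of the compounds shown alone.

Going by the values given here, compound 1 `CCn1c(SCC(=O)c2ccccc2)nnc1-c1ccc(OC)cc1` is one of three compounds measured in a functional assay on the whole organism (strain albino) for inhibition, with Rattus norvegicus as the target, read by paw edema, with a stated time of 3 h, at a dose of 0.28 mmol/kg by the oral route; a lower number here means less inhibition, a higher number more inhibition at the dose given (going by the name of the read-out); in that test compound 1 gives 67%. Among the three numbers it stands second highest. Its nearest neighbour is compound 3 `C=CCn1c(SC/C(=N/O)c2ccccc2)nnc1-c1cc(OC)c(OC)c(OC)c1`, which gives 70%, and the furthest is compound 2 `CCn1c(SCC(=O)c2ccccc2)nnc1-c1ccccc1`, which gives 61%; both gaps lie within the scatter of repeated measurements. Among the compounds with values here, the only step between two compounds differing in one place, a number 6 percentage points lower from compound 1 to compound 2 (within the scatter), comes from hydrogen in place of methoxy on an aromatic carbon and stays within the scatter.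

Compound 4 `COc1ccc(-c2nnc(SCC(=O)c3ccccc3)n2-c2ccccc2)cc1` differs from compound 1 by phenyl in place of ethyl on an aromatic nitrogen. Within the data shown here, no measured step touches the group on that aromatic nitrogen: compound 3 carries a different group there, but it also differs in other places, so its value shows only that compound 3 and compound 1 sit close together. With nothing pointing in either direction, the expected step of a number 2 percentage points lower from compound 1 to compound 4 (within the scatter) is none beyond the scatter. Compound 4 is therefore estimated at 65%, with a range from 50% to 78%.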

Compound 4, a percentage reported as inhibition, in the whole organism at one dose (the size of the read-out at that dose, not a potency): 58%
For compound 4 the middle estimate is 7 percentage points above the measured one; measured number inside the range.
By their numbers in this assay, from the lowest: compounds 4, 2, 1 and 3 (each within the scatter of the next, the first and the last beyond it).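

Phenyl is the first group other than ethyl whose effect can be read at this aromatic nitrogen of the shared core. In this assay, this change gives a number 9 percentage points lower from compound 1 to compound 4 (within the scatter), so the ring, with its larger count of heavy atoms, still leaves inhibition of paw swelling in the same range as ethyl. The other step in the series, the loss of methoxy, also lies within the scatter, so neither change shows a clear effect on the read-out, and no supporting data are available to interpret this result.

From the compounds shown here alone, what a benzyl group, or a chain ending in an amine or a carboxylic acid, would do on this nitrogen remains open. Going by these compounds, with a single dose and time point, it also remains open whether compound 1 and compound 4 would separate at other doses.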